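Isopropyl for Methyl: Expecting the Number for Compound 4

A few compounds are considered here, and "the series" means these few. Any claim that something is new, unique, unknown or untested is made for them only; others in the source may bear on it.

Measured so far in an assay on HeLa cells for displacement of a labelled ligand from 5-hydroxytryptamine receptor 6 (Homo sapiens); a lower number here means a stronger inhibitor, a higher number a weaker inhibitor:
Compound 1 `CCn1nc(S(=O)(=O)c2cccc3ccccc23)c2cc(N3CCN(C)CC3)ccc21`: 1.7 nM
Compound 2 `CN1CCN(c2ccc3[nH]nc(S(=O)(=O)c4ccc(Cl)cc4)c3c2)CC1`: 8.1 nM
Compound 3 `CN1CCN(c2cccc3c(S(=O)(=O)c4cccc5ccccc45)n[nH]c23)CC1`: 4.6 nM

Compound 1 holds the lowest number of the three in this assay, and both compound 3 and compound 2 sit beyond the usual scatter above it, so compound 1 is the strongest binder shown here. Compound 4 `CC(C)Cn1nc(S(=O)(=O)c2cccc3ccccc23)c2cc(N3CCN(C)CC3)ccc21` differs from compound 1 in a single place: isopropyl in place of methyl on a saturated chain carbon bound to an aromatic nitrogen. Within the data shown here, no measured pair in this set carries that change, so nothing in the data tells how it will read. The shared core and every other group stay the same, and the estimate is that the step of a 1.8-fold higher number from compound 1 to compound 4 (0.25 log units; within the scatter) remains small, at most a little weaker. Compound 4 is therefore expected to give about 3 nM, within a range from 1 nM to 10 nM.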

Compound 4, inhibition constant: 1.4 nM
Compound 4: the middle estimate sits 2.1-fold (0.33 log units) above what was measured, and the stated range covers the measured number.
By their numbers in this assay, from the lowest: compounds 4 and 1 (each within the scatter of the next); then compounds 3 and 2 (each within the scatter of the next).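

In this assay isopropyl in place of methyl on a saturated chain carbon bound to an aromatic nitrogen gives a 1.2-fold lower number from compound 1 to compound 4 (0.08 log units; within the scatter) and so leaves the binding number unchanged within the scatter. Among these compounds, this is the first pair in the set that differs in one place, and it shows that this position holds isopropyl as well as methyl. Nothing available here accounts for that result. Going by these compounds, whether an amine, a carboxylic acid or a phenyl ring at the end of the chain would be held as well stays open, and so does the reading for a longer chain.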